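Swapping the aryl group on the chain in a thioenone series

The compounds below may be only part of what the source reports. "The series", "measured", "known", "first", "only" and "open" are said of these compounds alone.

Compound 1, `O=C(/C(=C\c1ccc(F)cc1F)Sc1ccc(Br)cc1)c1ccc(Br)cc1`, is measured in a functional assay on DU-145 cells (Homo sapiens) for inhibition, read by trypan blue exclusion, with a stated time of 96 h (a higher number here means a weaker inhibitor of growth, a lower number a stronger inhibitor of growth), where compound 1 gives 1000 nM. Compound 3, `O=C(/C(=C\c1ccc(Oc2ccccc2)cc1)SCc1ccccc1Cl)c1ccc(Cl)cc1`, gives 1000 nM in this assay, so compound 1 stands level with compound 3 at the digits shown, within the scatter. Compound 2, `Cc1ccc(S/C(=C/c2ccc(F)cc2F)C(=O)c2ccc(Br)cc2)cc1`, reaches only the limit of this assay at > 100000 nM, which is a limit and not a number. Among the compounds with values here, the one single-point step measured, an at least 100-fold higher number from compound 1 to compound 2 (2.00 log units; beyond the scatter), leaves the chain untouched and changes a group on an aromatic carbon, and it ends at a limit (the limit of > 100000 nM in this assay, at which 1 of the 3 values shown sits).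

Compound 4, `O=C(/C(=C\c1ccc(Br)cc1)Sc1ccc(Br)cc1)c1ccc(Br)cc1`, differs from compound 1 by 4-bromophenyl in place of 2,4-difluorophenyl on a double-bonded chain carbon bound to a double-bonded chain carbon. Within the data shown here, no measured step alters the 2,4-difluorophenyl at that position, and compound 3 carries other changes besides, so nothing here points in either direction for this assay. The step from compound 1 to compound 4 is therefore expected to be none beyond the scatter, no change at the digits printed from compound 1 to compound 4 (within the scatter). Compound 4 is estimated at 1000 nM, with a range from 300 nM to 3500 nM.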

Compound 4, concentration for 50% growth inhibition: 1000 nM
Beside the measured number, compound 4's estimate shows no gap at the digits printed; measured number inside the range.
By their numbers in this assay, from the lowest: compounds 1, 3 and 4 (each within the scatter of the next). At a limit, above all of these: compound 2.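

At the double-bonded chain carbon, putting 4-bromophenyl in place of 2,4-difluorophenyl in this assay gives no change at the digits printed from compound 1 to compound 4 (within the scatter). Within the data shown here, the one earlier step, an at least 100-fold higher number from compound 1 to compound 2 (2.00 log units; beyond the scatter), changed a different place and ended at a limit of the assay, so this is the first reading at this position, and here two quite different aryl groups give the same number. Nothing measured here offers a reason for that sameness.

As far as these compounds go, two aryl groups say little about the position as a whole, so it remains open whether an amine, a carboxylic acid or a longer chain at this carbon would keep the number in place. Also open, from the compounds shown here alone, is whether the same swap would leave the number unmoved on the core of compound 2 or compound 3.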